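The compounds below may be only part of what the source reports. "The series", "measured", "known", "first", "only" and "open" are said of these compounds alone.

Of the compounds shown here, three have been measured so far in a functional assay on HL-60 cells (Homo sapiens) for antiproliferative activity, tested at 100 uM; on this read-out higher numbers stand for a stronger effect at the one concentration tested and lower numbers for a weaker effect. Compound 1 `Cc1cc2cc(NS(=O)(=O)Cc3ccc(C(=O)NO)cc3)ccc2n(C)c1=O` gives 27%, compound 2 `COC(=O)c1ccc(S(=O)(=O)Nc2ccc3c(c2)cc(C)c(=O)n3C)c(OC)c1` gives 68%, and compound 3 `COc1ccc(C(=O)NO)cc1CS(=O)(=O)Nc1ccc2c(c1)cc(C)c(=O)n2C` gives 0%. Compound 3 therefore has the lowest of the three numbers: compound 1 lies higher by a margin beyond the usual scatter, and compound 2 lies higher still, also beyond the scatter.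

Compound 4 `Cc1cc2cc(NS(=O)(=O)Cc3cccc(C(=O)NO)c3)ccc2n(C)c1=O` differs from compound 3 in a single place: hydrogen in place of methoxy on an aromatic carbon. Among the measured compounds shown here, no two measured compounds differ in just one place, so the size of such a swap has not been seen directly here. A small upward step in this assay is expected, written as a number 15 percentage points higher from compound 3 to compound 4 (beyond the scatter). Compound 4 is accordingly estimated at 15%, most likely between 0% and 40%.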

Compound 4, a percentage reported as inhibition, at one concentration (the size of the read-out at that concentration, not a potency): 0%
Compound 4: middle estimate off by 15 percentage points, on the high side; low and high end bracket the measured number.
By their numbers in this assay, from the lowest: compounds 3 and 4 (each within the scatter of the next); then compound 1; then compound 2.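

Among the compounds shown here, this is the first step in the set that changes one place only: with hydrogen in place of methoxy on the aromatic carbon para to a hydroxycarbamoyl group, this assay shows no change at the digits printed from compound 3 to compound 4 (within the scatter). Both compounds sit at the floor of this read-out, so the step cannot tell what the methoxy contributes at this position. The data offer no explanation for this result.

As far as these compounds go, whether an amine or a carboxylic acid on this carbon would read differently from compound 3 stays open. So does whether the same swap would show a step in a compound that starts well above the floor.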